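A Methyl for a Fluoro on Compound 3

This account rests on a few compounds, and the source may have more. Where it says the series, first, only, none or still open, it means among the compounds named here.

In an ADME assay on HEK-293T cells (Homo sapiens) for inhibition, read by CCK-8 assay, with a stated time of 48 h, tested at 20 uM (a higher number here means more inhibition of growth at the concentration tested, a lower number less inhibition of growth), compound 1 (`Cc1ccc(S(=O)(=O)Oc2ccccc2/C=C(\C#N)C(=O)Nc2nnc(Cc3ccc(F)cc3)s2)cc1`) gives 16%, and compound 2 (`N#C/C(=C\c1ccccc1OS(=O)(=O)c1ccc([N+](=O)[O-])cc1)C(=O)Nc1nnc(Cc2ccc(F)cc2)s1`) gives 8%. Compound 3 (`N#C/C(=C\c1ccccc1OS(=O)(=O)c1ccc(F)cc1)C(=O)Nc1nnc(Cc2ccc(F)cc2)s1`) has no single number and is recorded only as "not toxic" (no number reported). Compound 4 (`Cc1ccc(Cc2nnc(NC(=O)/C(C#N)=C/c3ccccc3OS(=O)(=O)c3ccc(F)cc3)s2)cc1`) differs from compound 3 in one place: methyl in place of fluoro on an aromatic carbon. This puts methyl in place of fluoro on an aromatic carbon, turning the 4-fluorobenzyl into a 4-methylbenzyl. Within the data shown here, the only measured step is a number 8 percentage points lower from compound 1 to compound 2 (within the scatter). It concerns a different group, so it offers only indirect guidance. No step beyond the scatter is therefore expected in this assay. Compound 4 is estimated to give 12%, within an expected range of 0% to 25%.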

Compound 4, percent growth inhibition at one concentration: 11%
The estimate for compound 4 lay 1 percentage points above the measured number; measured number inside the range.
By their numbers in this assay, from the lowest: compounds 2, 4 and 1 (each within the scatter of the next).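

In this assay, among these compounds, compound 4 gives 11%, but compound 3 carries only the words "not toxic", and no step between compound 3 and compound 4 can be read. From the compounds shown here alone, what swapping fluoro for methyl does to growth inhibition stays open. No measurement shown here speaks to a cause.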